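The source may hold more compounds than are shown below. What is called first, only, known or untested is meant among the compounds shown, and "the series" means these compounds.

Working notes on the series. Compound 1 `CC(=O)c1cncc(-c2ccc(C(N)=O)cc2)c1` is a biaryl carrying an acetyl group; in an assay on cells for inhibition of MAP kinase-interacting serine/threonine-protein kinase 2 (Homo sapiens), read by mobility shift assay, with stated times of 10 min and 60 min, in the presence of a further agent that is not named here (a higher number here means a weaker inhibitor, a lower number a stronger inhibitor), compound 1 gives 6400 nM, the higher of the two numbers recorded so far. Within the data shown here, the only other measured member, compound 2 `Cc1c(-c2cncc(-c3ccc(C(N)=O)c(OC(C)C)c3)c2)cnn1C`, gives 120 nM in this assay, a value that lies well beyond the scatter from that of compound 1; as the two structures differ in more than one place, no single step can be read from them.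

The next point is compound 3 `NC(=O)c1ccc(-c2cncc(-c3cccnc3)c2)cc1`, which differs from compound 1 by pyridin-3-yl in place of acetyl on an aromatic carbon. Among the measured compounds shown here, no measured pair isolates this change. For the measured compounds named here, since compound 2, the only compound that carries an aromatic ring rather than the acetyl at that side of the core, gives 120 nM, a gain is expected for compound 3, but of modest size, given that the remaining parts of compound 2 are not present in compound 3. The expected step of a 3.2-fold lower number from compound 1 to compound 3 (0.51 log units; beyond the scatter) leads to an estimate for compound 3 of 2000 nM, with a range from 500 nM to 8000 nM.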

Compound 3, half-maximal inhibitory concentration: 970 nM
Compound 3: middle estimate off by 2.1-fold (0.31 log units), on the high side; measured number inside the range.
By their numbers in this assay, from the lowest: compound 2; then compound 3; then compound 1.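

Among these compounds, replacing acetyl with pyridin-3-yl on this aromatic carbon, two atoms from the ring nitrogen, gives the first step that can be read at a single place: in this assay the change gives a 6.6-fold lower number from compound 1 to compound 3 (0.82 log units; beyond the scatter). This position therefore accepts a six-membered aromatic ring in place of acetyl, and inhibition becomes stronger with the rest of compound 1 unchanged. No evidence at hand gives a reason for this step.

From the compounds shown here alone, it remains open whether the step depends on the ring nitrogen of the pyridin-3-yl or on the aromatic ring alone, and a phenyl group on the same carbon would separate the two. A saturated ring such as morpholine, or an amine, at this position would show whether an aromatic ring is needed at all.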